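Amide coumarins on MCF7 cells: amine replacement at the chain end

A few compounds are considered here, and "the series" means these few. Any claim that something is new, unique, unknown or untested is made for them only; others in the source may bear on it.

Measured so far:
compound 1 `CC(=O)Oc1ccc(C(=O)Nc2cc3ccc(OCC4CCCN(C)C4)c(C)c3oc2=O)cc1CC=C(C)C`, 1650 nM
compound 2 `CC(=O)Oc1ccc(C(=O)Nc2cc3ccc(OCCC4CCCCN4)c(C)c3oc2=O)cc1CC=C(C)C`, 710 nM
compound 3 `CC(C)=CCc1cc(C(=O)Nc2cc3ccc(OCCCN(C(C)C)C(C)C)c(C)c3oc2=O)ccc1O`, 1310 nM

In a functional assay on MCF7 cells (Homo sapiens) for antiproliferative activity (on this read-out higher numbers stand for weaker inhibition and lower numbers for stronger inhibition), compound 3 stands second highest of the three; its gap to compound 1 is within the scatter, and its gap to compound 2 is also within the scatter. Compound 4 `CC(C)=CCc1cc(C(=O)Nc2cc3ccc(OCCCN[C@@H]4C[C@H]5CC[C@@H]4C5)c(C)c3oc2=O)ccc1O` differs from compound 3 by a group of 8 heavy atoms (7 carbon, 1 nitrogen; 2 five-membered non-aromatic rings of carbon only) in place of a group of 7 heavy atoms (6 carbon, 1 nitrogen; no ring), on a saturated chain carbon, three bonds along the chain from an oxygen on an aromatic ring. Going by the values given here, the only measured step that touches the amine end of this chain is a 2.3-fold lower number from compound 1 to compound 2 (0.37 log units; beyond the scatter), where a tertiary amine gave way to one bearing a hydrogen-bond donor; compound 4 likewise gains one donor. On that slender basis a modest downward step is expected, a 1.5-fold lower number from compound 3 to compound 4 (0.19 log units; within the scatter), and compound 4 is estimated at 850 nM, with a range from 320 nM to 2400 nM.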

Compound 4, half-maximal inhibitory concentration: 1030 nM
Beside the measured number, compound 4's estimate is 1.2-fold (0.08 log units) below it; the range from low to high includes it.
By their numbers in this assay, from the lowest: compounds 2, 4, 3 and 1 (each within the scatter of the next, the first and the last beyond it).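

In this assay the chain end tolerates replacing diisopropylamino with the group of 8 heavy atoms bearing 2 five-membered non-aromatic rings: a 1.3-fold lower number from compound 3 to compound 4 (0.10 log units; within the scatter). Adding a ring-bearing group and a hydrogen-bond donor at this position therefore leaves the read-out within the scatter, unlike the earlier amine step, a 2.3-fold lower number from compound 1 to compound 2 (0.37 log units; beyond the scatter). On these data alone, whether a morpholine or a carboxylic acid at this chain end would shift the read-out remains open. Also open, as far as these compounds go, is whether this replacement behaves alike with an acetate ester in place of the free hydroxyl. No supporting evidence is available to explain this result.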